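The source may hold more compounds than are shown below. What is called first, only, known or untested is meant among the compounds shown, and "the series" means these compounds.

Working notes on the series

Compound 3 `CC(C)(CCCC/C=C(\c1ccccc1)c1cccnc1)C(=O)O` gives 45 nM in an assay (Equus caballus) for inhibition of Thromboxane-A synthase (Homo sapiens), using microsomes (a lower number here means a stronger inhibitor, a higher number a weaker inhibitor), the second highest of the three numbers, with compound 2 `COCC(CCC/C=C(\c1ccccc1)c1cccnc1)C(=O)O` nearest at 41 nM and compound 1 `O=C(O)CCCCCCCCC/C=C(\c1ccccc1)c1cccnc1` furthest at 55 nM; all three sit within the scatter of each other. Compound 4 `O=C(O)CCC/C=C(\c1ccccc1)c1cccnc1` differs from compound 3 by carboxy in place of 2-carboxy-2-methylpropyl on a saturated chain carbon, three bonds along the chain from a double-bonded chain carbon. Within the data shown here, the steps that bear on this are a 1.2-fold lower number from compound 1 to compound 3 (0.09 log units; within the scatter) and a 1.1-fold higher number from compound 2 to compound 3 (0.04 log units; within the scatter), both within the scatter, so variation of the chain carrying the carboxy has so far left this assay unmoved. The cut here is deeper than either, and a modest weakening is expected, a 3.3-fold higher number from compound 3 to compound 4 (0.52 log units; beyond the scatter). Compound 4 is estimated at 150 nM, with a range of 40 nM to 600 nM.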

Compound 4, half-maximal inhibitory concentration: 30 nM
Compound 4: the middle estimate sits 5.0-fold (0.70 log units) above what was measured; the measured number lies below the stated range.
By their numbers in this assay, from the lowest: compounds 4, 2, 3 and 1 (each within the scatter of the next).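

Carboxy in place of 2-carboxy-2-methylpropyl is a deeper cut at this position than the earlier steps, yet in this assay both a 1.5-fold lower number from compound 3 to compound 4 (0.18 log units; within the scatter) and a 1.4-fold lower number from compound 2 to compound 4 (0.14 log units; within the scatter) remain within the scatter. The branched 2-carboxy-2-methylpropyl and 1-carboxy-2-methoxyethyl groups are therefore not required for a value in this range, at least in compound 4. Nothing shown here explains this tolerance.

As far as these compounds go, what an amide or a hydroxymethyl in place of the carboxy would give in this assay stays open, as does a chain shorter than that of compound 4.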